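A few compounds are considered here, and "the series" means these few. Any claim that something is new, unique, unknown or untested is made for them only; others in the source may bear on it.

Measured so far in an assay on isolated protein for binding affinity to corticotropin-releasing factor receptor 1 (Homo sapiens); a lower number here means a stronger inhibitor, a higher number a weaker inhibitor:
compound 1 `CC(=O)/C(=N\Nc1ccccc1C(F)(F)F)Nc1cccc(Cl)c1`: 538 nM; 538 nM (2 entries)
compound 2 `CSc1cccc(N/C(=N/Nc2ccccc2C)C(C)=O)c1`: > 10000 nM
compound 3 `COc1cccc(N/C(=N/Nc2ccccc2C(F)(F)F)C(C)=O)c1`: 6950 nM

The value of compound 2 is a limit of this assay and not a number; (the limit of > 10000 nM in this assay, at which 1 of the 3 values shown sits). Compound 3 is the only entry with a single number in this assay, and that number sits well above the two entries of compound 1. Compound 4 `CSc1cccc(N/C(=N/Nc2ccccc2C(F)(F)F)C(C)=O)c1` has not been measured. It differs from compound 3 in one place: methylsulfanyl in place of methoxy on an aromatic carbon. Among the measured compounds shown here, compound 2 also carries methylsulfanyl and gives only a limit, so no step for this exchange has been measured. The expected step from compound 3 to compound 4 in this assay is a 1.3-fold higher number from compound 3 to compound 4 (0.11 log units; within the scatter), toward weaker binding or no change beyond the scatter. Compound 4 is estimated at 9000 nM, with a range from 3000 nM to 25000 nM.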

Compound 4, inhibition constant: > 10000 nM
Compound 4: only a limit was reported (the forecaster's own chance of this, stated with the estimate: 40%); middle value at least 1.1-fold (0.04 log units) away from the limit.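

In this assay, among the compounds shown here, methylsulfanyl in place of methoxy on this aromatic carbon gives an at least 1.4-fold higher number from compound 3 to compound 4 (0.15 log units; that floor lies within the scatter), the first readable step for this exchange, though only as a floor. Compound 4 gives a limit of the assay and not a number, which makes the true size of that step unknown: the limit of > 10000 nM in this assay, at which 2 of the 4 values shown sit. The step from compound 2 to compound 4 cannot be read, so trifluoromethyl in place of methyl has no size here.

As far as these compounds go, how far compound 4 sits past its limit remains open. Also open, from the compounds shown here alone, is whether an amine or an ethoxy group at this position would read closer to compound 1 at 538 nM; 538 nM (2 entries).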